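A few compounds are considered here, and "the series" means these few. Any claim that something is new, unique, unknown or untested is made for them only; others in the source may bear on it.

In a functional assay on CCRF-CEM cells (Homo sapiens) for inhibition (on this read-out lower numbers stand for higher toxicity in this test and higher numbers for lower toxicity in this test), compound 1 `O=C1c2ccccc2N(COCc2ccccc2)S(=O)(=O)N1Cc1ccccc1` gives 25000 nM. Compound 2 `O=S1(=O)N=C(OCc2ccccc2)c2ccccc2N1Cc1ccc(Cl)c(Cl)c1` gives 30500 nM in this assay, a number so close to that of compound 1 that the two cannot be told apart within the usual scatter. Compound 3 `O=C1c2ccccc2N(Cc2ccccc2)S(=O)(=O)N1Cc1ccccc1Cl` reaches only a limit of this assay, > 250000 nM, so no measured number exists for it. Compound 4 `O=C1c2ccccc2N(Cc2cccc(Cl)c2)S(=O)(=O)N1Cc1ccccc1` has not yet been tested in this assay. It differs from compound 1 in one place: 3-chlorophenyl in place of benzyloxy on a saturated chain carbon bound to a sulfonamide nitrogen in a ring. Among the measured compounds shown here, no measured pair of compounds differs in exactly this way, so the size of this step cannot be read from the measurements at hand. The limit seen for compound 3, (the limit of > 250000 nM in this assay, at which 1 of the 3 values shown sits), shows that among these compounds a change at the benzylic positions can carry the number out of the measurable range. For compound 4 a step toward a higher number, a 2.4-fold higher number from compound 1 to compound 4 (0.38 log units; beyond the scatter), is expected, though with little confidence. The estimate for compound 4 is 60000 nM, with a range from 15000 nM to 250000 nM.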

Compound 4, half-maximal cytotoxic concentration: 2100000 nM
Estimate against measurement, compound 4: 35-fold (1.54 log units) below, and the stated range ends below it.
By their numbers in this assay, from the lowest: compounds 1 and 2 (each within the scatter of the next); then compound 4.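

Replacing benzyloxy with 3-chlorophenyl on this saturated chain carbon bound to a sulfonamide nitrogen in a ring gives, in this assay, an 84-fold higher number from compound 1 to compound 4 (1.92 log units; beyond the scatter), which shows that this one place alone can shift the read-out strongly toward lower toxicity in this test. Both groups hold one six-membered aromatic ring of carbon only, so such a ring at this place does not by itself keep the number low. Compound 3 offers no number to set beside this step, only a limit of the assay: the limit of > 250000 nM in this assay, at which 1 of the 4 values shown sits.

The compounds shown leave open how much of the step belongs to the chlorine that enters and how much to the oxygen that leaves. They also leave open how this place would respond to a different kind of group, such as an amine or a carboxylic acid at the end of a longer chain.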